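Aryl variation at the thiazole-adjacent position: efficacy notes

The compounds below may be only part of what the source reports. "The series", "measured", "known", "first", "only" and "open" are said of these compounds alone.

Compound 1 `O=C(O)Cc1sc(C(c2ccc(F)cc2)c2ccc(F)cc2)nc1-c1cc(F)cc(F)c1` and compound 2 `O=C(O)Cc1sc(C(c2ccc(F)cc2)c2ccc(F)cc2)nc1-c1cn[nH]c1` share the same core and differ in the group carried on the aromatic carbon that also sits next to the ring nitrogen. In an in vitro functional assay on HEK285-7 cells for antagonist activity at prostaglandin D2 receptor 2 (Homo sapiens), read by BRET and beta-arrestin recruitment (a lower number here means a smaller maximal response, a higher number a larger maximal response), compound 1 gives 80%; in this assay compound 2 gives 80%. The step of no change at the digits printed from compound 1 to compound 2 (within the scatter) shows that swapping 3,5-difluorophenyl for 1H-pyrazol-4-yl left the maximal response level with that of compound 1, so compound 2 stands level with compound 1 on the numbers shown.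

Compound 3 `O=C(O)Cc1sc(C(c2ccc(F)cc2)c2ccc(F)cc2)nc1-c1ccoc1` continues at the same place: furan-3-yl in place of 1H-pyrazol-4-yl on an aromatic carbon. Within the data shown here, the only step that bears on it is no change at the digits printed from compound 1 to compound 2 (within the scatter), which is within the scatter, so an aryl exchange at this position has so far not moved the maximal response. For compound 3 in this assay a step of no change at the digits printed from compound 2 to compound 3 (within the scatter) is therefore expected, that is none beyond the scatter. Compound 3 is estimated at 80%, with a range of 65% to 93%.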

Compound 3, largest response reached (reported as efficacy), in percent of the reference or control that the assay uses: 80%
Beside the measured number, compound 3's estimate shows no gap at the digits printed, within the range that was stated.
By their numbers in this assay, from the lowest: compounds 1, 2 and 3 (each within the scatter of the next).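

In this assay furan-3-yl, with 0 hydrogen-bond donors, in place of 1H-pyrazol-4-yl, with 1 hydrogen-bond donor, gives no change at the digits printed from compound 2 to compound 3 (within the scatter) and so the maximal response of this pair does not follow the presence of that donor on the group. Furan-3-yl in place of 3,5-difluorophenyl gives no change at the digits printed from compound 1 to compound 3 (within the scatter) and so a five-membered aromatic ring with 1 hetero atom also stands level with the fluorinated phenyl group, making three aromatic groups at this carbon with no separation in maximal response. Nothing available explains this flat response at the position.

The compounds shown leave open whether a group without an aromatic ring at this carbon, such as a primary amine or a morpholine, would stay level with these three. On these data alone, whether pyridin-4-yl would do so also remains open.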